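Carboxy for silyl ether on an inactive triazole series

The compounds below may be only part of what the source reports. "The series", "measured", "known", "first", "only" and "open" are said of these compounds alone.

Compound 3 `Cn1c(Cc2nn(CCCO[Si](C)(C)C(C)(C)C)c(=O)c3ccccc23)nnc1SCCCCCCCC(=O)Nc1ccc(Cl)cc1Cl` stands only at a limit in an assay on NK92 cells for inhibition of interleukin-15 (Homo sapiens), read by AlphaScreen, with stated times of 30 min and 1 h; a higher number here means a weaker inhibitor, a lower number a stronger inhibitor: in this assay compound 3 gives > 30000 nM, a limit and not a number. Compound 1 `Cn1nc(Cc2nnc(SCC(=O)Nc3ccc(Cl)cc3Cl)n2CCC(=O)O)c2ccccc2c1=O` likewise gives a limit, > 30000 nM, in this assay. Compound 2 `Cn1c(Cc2nn(CCC3OCCO3)c(=O)c3ccccc23)nnc1SCC(=O)Nc1ccc(Cl)cc1Cl` gives 30000 nM in this assay. Two of the three values thus sit at the limit of > 30000 nM in this assay, at which 2 of the 3 values shown sit. Compound 4 `Cn1c(Cc2nn(CCC(=O)O)c(=O)c3ccccc23)nnc1SCCCCCCCC(=O)Nc1ccc(Cl)cc1Cl` differs from compound 3 by a group of 3 heavy atoms (1 carbon, 2 oxygen; no ring) in place of a group of 9 heavy atoms (7 carbon, 1 oxygen, 1 silicon; no ring), on a saturated chain carbon, two bonds along the chain from an aromatic nitrogen, on a saturated chain carbon, two bonds along the chain from an aromatic nitrogen. Within the data shown here, no measured pair differs in one place, so no step size is known. The expected step of a number no higher from compound 3 to compound 4 (the limit leaves the size open) is none beyond the scatter. Compound 1 carries the same carboxy group and gives > 30000 nM in this assay, which supports that expectation. Compound 4 is expected to give 30000 nM, within 10000 nM to 60000 nM, most likely again only a limit.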

Compound 4, half-maximal inhibitory concentration: > 30000 nM
Compound 4: only a limit was reported; the forecaster's own chance of this, stated with the estimate: 70%; the middle value sits exactly at the limit.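

Compound 3 and compound 4 both stand only at a limit in this assay, so no step between them can be read: the limit of > 30000 nM in this assay, at which 3 of the 4 values shown sit.

The compounds shown leave open whether carboxy in this place changes inhibition at all.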